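Phenyl in Place of Thiophen-2-yl: Expectation for Compound 4

A few compounds are considered here, and "the series" means these few. Any claim that something is new, unique, unknown or untested is made for them only; others in the source may bear on it.

Compound 1 `CC1CCCc2c1nc(N)c(C#N)c2-c1cccn1C`: 3390 nM
Compound 2 `Cn1cccc1-c1cc(-c2cccs2)nc(N)c1C#N`: 5370 nM
Compound 3 `CC1CCCc2c1[nH]c(=O)c(C#N)c2-c1cccn1C`: > 100000 nM

In a functional assay on SR cells (Homo sapiens) for inhibition, read by sulforhodamine B assay, with a stated time of 48 h (on this read-out lower numbers stand for stronger inhibition of growth and higher numbers for weaker inhibition of growth), compound 2 gives the highest of the two numbers, and its nearest neighbour, compound 1, sits within the scatter of it. Compound 3 reaches only (the limit of > 100000 nM in this assay, at which 1 of the 3 values shown sits), a limit and not a number. Compound 4 `Cn1cccc1-c1cc(-c2ccccc2)nc(N)c1C#N` has not been measured in this assay. It differs from compound 2 by phenyl in place of thiophen-2-yl on an aromatic carbon. Within the data shown here, no step between measured compounds covers this change, so the expected step is none beyond the scatter. Compound 4 is therefore estimated at 5000 nM, with a range from 2000 nM to 15000 nM. That estimate means an expected step of a 1.1-fold lower number from compound 2 to compound 4 (0.03 log units; within the scatter), which is expected to stay within the scatter.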

Compound 4, concentration for 50% growth inhibition: 35500 nM
The estimate for compound 4 lay 7.1-fold (0.85 log units) below the measured number; the whole stated range lies below it.
By their numbers in this assay, from the lowest: compounds 1 and 2 (each within the scatter of the next); then compound 4. At a limit, above all of these: compound 3.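

In this assay the aromatic group on the carbon next to the ring nitrogen proves not to be freely exchangeable: phenyl in place of thiophen-2-yl brings a 6.6-fold higher number from compound 2 to compound 4 (0.82 log units; beyond the scatter) on an otherwise unchanged core. Among these compounds, the earlier compounds held no step at this position, so this is the first sign that the read-out responds to the group there. Nothing measured here gives a cause for this step.

Open, on these data alone, is how smaller or non-aromatic groups on this carbon, such as an amine or a methyl group, would compare with thiophen-2-yl. As far as these compounds go, whether a furan-2-yl or pyridin-2-yl ring would stay near compound 2 or move towards compound 4 also remains open.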